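Dropping One Methoxy from a Sulfonamide Growth Inhibitor

The source may hold more compounds than are shown below. What is called first, only, known or untested is meant among the compounds shown, and "the series" means these compounds.

Measured so far:
- compound 1, `COc1ccc(CNCCCNS(=O)(=O)c2cc(C(F)(F)F)cc(C(F)(F)F)c2)cc1OC`: 2700 nM
- compound 2, `CC(C)(C)c1ccc(CNCCNS(=O)(=O)c2cc(C(F)(F)F)cc(C(F)(F)F)c2)cc1`: 14000 nM

Two compounds have numbers in a functional assay on HT-29 cells (Homo sapiens) for inhibition, read by MTT assay, with a stated time of 72 h; on this read-out higher numbers stand for weaker inhibition of growth and lower numbers for stronger inhibition of growth. Compound 1 gives 2700 nM, the lower of the two. Compound 2 gives 14000 nM, a higher number that lies beyond the usual scatter, so compound 1 is the stronger growth inhibitor of the pair. Compound 2 differs from compound 1 in more than one place, so the two values alone do not tell which change matters.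

The next compound, compound 3, `COc1cccc(CNCCCNS(=O)(=O)c2cc(C(F)(F)F)cc(C(F)(F)F)c2)c1`, is a closer relative of compound 1. The change is hydrogen in place of methoxy on an aromatic carbon. The rest of the structure, including the shared core bearing two trifluoromethyl groups and the three-carbon chain between the two nitrogen atoms, is unchanged.

Among the measured compounds shown here, no pair of measured compounds separated by a single change exists here, so the size of this step is not anchored by any measurement. A single methoxy is a small piece of the molecule, and the step from compound 1 to compound 3 is expected to be modest: a 1.5-fold higher number from compound 1 to compound 3 (0.17 log units; within the scatter), leaning toward a somewhat higher number but possibly within the scatter. Compound 3 is therefore estimated at 4000 nM in this assay, with a plausible range from 1500 nM to 12000 nM.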

Compound 3, concentration for 50% growth inhibition: 10000 nM
For compound 3 the middle estimate is 2.5-fold (0.40 log units) below the measured one, within the range that was stated.
By their numbers in this assay, from the lowest: compound 1; then compounds 3 and 2 (each within the scatter of the next).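

Taking away this methoxy turns the 3,4-dimethoxybenzyl group of compound 1 into the 3-methoxybenzyl group of compound 3, and in this assay the step is a 3.7-fold higher number from compound 1 to compound 3 (0.57 log units; beyond the scatter). Among the compounds shown here, this is the first comparison in which only one place changes, so a difference in growth inhibition can now be tied to a single spot on the aromatic ring, para to a large group. With methoxy at this position the compound is the stronger growth inhibitor, and with hydrogen there it is clearly weaker, yet nothing measured here says what lies behind the rise in the number.

The compounds shown hold only methoxy or hydrogen at this position, so it remains open how a fluorine atom, a hydroxyl group or an ethoxy group there would compare. A plain benzyl group, carrying no methoxy at all, would show what the remaining methoxy of compound 3 contributes to growth inhibition in this assay on this shared core.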